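The source may hold more compounds than are shown below. What is called first, only, known or untested is meant among the compounds shown, and "the series" means these compounds.

Measured so far:
compound 1 `C=CCOC(=O)C1=C(C)NC(C)=C(C(=O)OC)C1c1cccc([N+](=O)[O-])c1` gives 15 nM in a functional assay on HEK293 cells for antagonist activity at Voltage-dependent L-type calcium channel subunit alpha-1D (Rattus norvegicus), read by FLIPR; a lower number here means a stronger inhibitor, a higher number a weaker inhibitor;
compound 2 `COC(=O)C1=C(C)NC(C)=C(C(=O)OCc2ccc(OC)c(OC)c2)C1c1cccc([N+](=O)[O-])c1` gives 117 nM in this assay.

Within the data shown here, compound 2 holds the highest number of the two; the only step that bears on it, a 7.8-fold higher number from compound 1 to compound 2 (0.89 log units; beyond the scatter), is modest but beyond the scatter. Compound 3 `COC(=O)C1=C(C)NC(C)=C(C(=O)OCCOCc2ccccc2)C1c1cccc([N+](=O)[O-])c1` is not yet measured. Its change from compound 2 is (benzyloxy)methyl in place of 3,4-dimethoxyphenyl on a saturated chain carbon bound to an oxygen next to a carbonyl group, at the same place where that single step acted. Among the measured compounds shown here, only one such step is known, and it ran from a small group to an aromatic one, so no clear direction follows for swapping one aromatic-bearing group for another. The step from compound 2 to compound 3 is therefore expected to stay small, around a 1.5-fold lower number from compound 2 to compound 3 (0.17 log units; within the scatter). Compound 3 is estimated at 80 nM, within 25 nM to 260 nM.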

Compound 3, half-maximal inhibitory concentration: 12 nM
Compound 3: the middle estimate sits 6.7-fold (0.82 log units) above what was measured; measured number outside the range, below it.
By their numbers in this assay, from the lowest: compounds 3 and 1 (each within the scatter of the next); then compound 2.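

Replacing 3,4-dimethoxyphenyl with (benzyloxy)methyl gives a 9.8-fold lower number from compound 2 to compound 3 (0.99 log units; beyond the scatter) and so shows that carrying an aromatic ring at this position does not by itself go with a higher number in this assay. Replacing vinyl with (benzyloxy)methyl gives a 1.3-fold lower number from compound 1 to compound 3 (0.10 log units; within the scatter) and so leaves these two groups indistinguishable here. No measured evidence explains why the two aromatic groups differ. The compounds shown leave open whether the oxygen in (benzyloxy)methyl matters, and how an amine, a carboxylic acid or a longer chain would fare at this position.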